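Swapping phenyl for pyridin-4-yl on a shared core

The source may report more compounds than this note shows. Statements on the series, on what has been measured and on what is new or still open speak of the compounds shown alone.

Measured compounds:
compound 1 `Oc1cccc(-c2cc(-c3ccc(Cl)cc3)nc(-c3ccccn3)c2)c1`, 13900 nM
compound 2 `Oc1cccc(-c2cc(-c3ccccc3)nc(-c3ccc(Cl)cc3)c2)c1`, 11300 nM

Of the compounds shown here, two have been measured in a functional assay on T47D cells (Homo sapiens) for cytotoxicity, read by CCK-8 assay and cell counting, with a stated time of 2 days; a higher number here means a weaker inhibitor, a lower number a stronger inhibitor. Compound 1 gives 13900 nM in this assay. Compound 2 gives 11300 nM in this assay, which is the lower of the two numbers, but the step of a 1.2-fold lower number from compound 1 to compound 2 (0.09 log units; within the scatter) lies within the scatter, so the two compounds cannot be told apart on these data.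

Compound 3 `Oc1cccc(-c2cc(-c3ccncc3)nc(-c3ccc(Cl)cc3)c2)c1` is not yet measured. It differs from compound 2 in one place: pyridin-4-yl in place of phenyl on an aromatic carbon. Among the compounds with values here, the only measured step on the shared core, a 1.2-fold lower number from compound 1 to compound 2 (0.09 log units; within the scatter), exchanged one six-membered aromatic ring for another at the same kind of position and produced no change beyond the scatter. That step bears on the present one only loosely, since it involved pyridin-2-yl rather than pyridin-4-yl. On this thin basis, no step beyond the scatter is expected in this assay for compound 3, so compound 3 is estimated at 11000 nM, with a range from 4500 nM to 27000 nM, which corresponds to an expected step of a 1.0-fold lower number from compound 2 to compound 3 (0.01 log units; within the scatter).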

Compound 3, half-maximal inhibitory concentration: 3330 nM
The estimate for compound 3 lay 3.3-fold (0.52 log units) above the measured number; measured number below the stated range.
By their numbers in this assay, from the lowest: compound 3; then compounds 2 and 1 (each within the scatter of the next).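

In this assay, this position turns out to respond to the ring it carries: the exchange of phenyl for pyridin-4-yl gives a 3.4-fold lower number from compound 2 to compound 3 (0.53 log units; beyond the scatter), a modest step but a real one on these data, whereas the earlier exchange of a six-membered aromatic ring gave only a 1.2-fold lower number from compound 1 to compound 2 (0.09 log units; within the scatter). The two pyridinyl groups are also not interchangeable here, since pyridin-4-yl in place of pyridin-2-yl gives a 4.2-fold lower number from compound 1 to compound 3 (0.62 log units; beyond the scatter), so that pyridin-4-yl stands apart from both of the other groups, while those two cannot be told apart from each other. Nothing available explains why the pyridin-4-yl compound carries the lower number.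

The compounds shown leave open where pyridin-3-yl would fall relative to these three, and whether a pyrimidinyl ring or a saturated ring such as piperidin-4-yl at the same place would lower the number further or lose the step. They also leave open whether the step survives when a methoxyphenyl or aminophenyl group replaces the 3-hydroxyphenyl group, or when an unsubstituted phenyl replaces the 4-chlorophenyl group.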